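The source may hold more compounds than are shown below. What is called first, only, known or untested is meant among the compounds shown, and "the series" means these compounds.

Measured so far:
- Compound 1 `O=C(/C=C/c1ccc([N+](=O)[O-])cc1)Nc1cc2c(Nc3ccc(F)c(Cl)c3)ncnc2cc1O[C@H]1CCOC1`: 12000 nM in a functional assay on A549 cells (Homo sapiens) for cytotoxicity, read by MTT assay, with a stated time of 72 h; a higher number here means a weaker inhibitor, a lower number a stronger inhibitor
- Compound 2 `COc1cc(/C=C/C(=O)Nc2cc3c(Nc4ccc(F)c(Cl)c4)ncnc3cc2O[C@H]2CCOC2)cc(OC)c1OC`: in this assay compound 2 gives 4150 nM
- Compound 3 `COc1ccc(/C=C/C(=O)Nc2cc3c(Nc4ccc(F)c(Cl)c4)ncnc3cc2O[C@H]2CCOC2)c(OC)c1OC`: in this assay compound 3 gives 70 nM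

Compound 3 has the lowest number of the three, so it is the strongest inhibitor here; its nearest neighbour is compound 2, and compound 1 is furthest away. Compound 4 `O=C(/C=C/c1ccc(Br)cc1)Nc1cc2c(Nc3ccc(F)c(Cl)c3)ncnc2cc1O[C@H]1CCOC1` differs from compound 3 in one place: 4-bromophenyl in place of 2,3,4-trimethoxyphenyl on a double-bonded chain carbon bound to a double-bonded chain carbon

For the measured compounds named here, two measured steps bear on this change, both leading to compound 3 and both large: a 170-fold lower number from compound 1 to compound 3 (2.23 log units; beyond the scatter) and a 59-fold lower number from compound 2 to compound 3 (1.77 log units; beyond the scatter). Both show that the 2,3,4-trimethoxyphenyl carries much of the strength of compound 3, and that a 4-nitrophenyl, like the 4-bromophenyl now entering, goes with a far higher number. Going by the values given here, no step with a 4-bromophenyl itself exists, so the size is uncertain, but a large rise in the number is expected, in the step of a 71-fold higher number from compound 3 to compound 4 (1.85 log units; beyond the scatter). Compound 4 is therefore estimated at 5000 nM in this assay, with a likely range from 1000 nM to 25000 nM.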

Compound 4, half-maximal inhibitory concentration: 35300 nM
Compound 4: the middle estimate sits 7.1-fold (0.85 log units) below what was measured, outside the stated range (above it).
By their numbers in this assay, from the lowest: compound 3; then compound 2; then compound 1; then compound 4.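

In this assay, compound 4 has the highest number of the four, so it is the weakest, and a 500-fold higher number from compound 3 to compound 4 (2.70 log units; beyond the scatter) shows that losing the 2,3,4-trimethoxyphenyl at this place costs even more than compound 1 had suggested. The 4-bromophenyl also falls short of the 3,4,5-trimethoxyphenyl, with an 8.5-fold higher number from compound 2 to compound 4 (0.93 log units; beyond the scatter) as the measured gap, so both trimethoxyphenyl compounds have lower numbers than compound 4. Even the small exchange of bromo in place of nitro on an aromatic carbon registers, as a 2.9-fold higher number from compound 1 to compound 4 (0.47 log units; beyond the scatter) shows, although this step is modest beside the large loss from compound 3.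

No measurement here explains these differences. As far as these compounds go, it also remains open whether a phenyl carrying a single methoxy group, or an amine, could keep a number as low as that of compound 3.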